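Trifluoromethyl for tert-butyl at the assay limit

The source may report more compounds than this note shows. Statements on the series, on what has been measured and on what is new or still open speak of the compounds shown alone.

compound 1 `Clc1cc2nc(Cl)n(Cc3ccccc3)c2cc1Cl` gives > 100000 nM (a limit)
compound 2 `CC(C)(C)c1ccc(Cn2c(Cl)nc3cc(Cl)c(Cl)cc32)cc1` gives > 100000 nM (a limit)

In a functional assay on KB cells (Homo sapiens) for inhibition (on this read-out lower numbers stand for stronger inhibition and higher numbers for weaker inhibition), compound 2 stands at > 100000 nM as a limit of the assay, not as a number. Compound 3 `FC(F)(F)c1ccc(Cn2c(Cl)nc3cc(Cl)c(Cl)cc32)cc1` has not been measured yet. It differs from compound 2 by trifluoromethyl in place of tert-butyl on an aromatic carbon, para to a large group.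

Among the compounds with values here, only one measured step bears on this change: a step that the two limits leave unreadable from compound 1 to compound 2 (tert-butyl in place of hydrogen on an aromatic carbon). That step has no readable size, so it offers no number to carry over. What compound 1 and compound 2 share is the limit of > 100000 nM in this assay, at which 2 of the 2 values shown sit, and that is the whole of the evidence. On that ground, compound 3 is expected to show no step beyond the scatter in this assay and will most likely be reported as a limit too. The expected change is a number no higher from compound 2 to compound 3 (the limit leaves the size open) and it is only an estimate. The estimate for compound 3 is 100000 nM (expected range 30000 nM to 200000 nM).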

Compound 3, half-maximal inhibitory concentration: > 100000 nM
Compound 3: a limit, no number (the forecaster's own chance of this, stated with the estimate: 80%); the middle value lies on the limit itself.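

In this assay compound 3 gives > 100000 nM, which is a limit of the assay and not a number. The steps linking compound 1, compound 2 and compound 3 therefore cannot be read, and the evidence is just this: the limit of > 100000 nM in this assay, at which 3 of the 3 values shown sit.

These compounds leave open how strongly, if at all, any of the three inhibits, and which change to the shared structure would give a measurable value.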